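The compounds below may be only part of what the source reports. "The series", "measured", "known", "first", "only" and "open" are said of these compounds alone.

Of the compounds shown here, three sharing one core have been tested in an ADME assay on Raji cells (Homo sapiens) for cytotoxicity, read by CellTiter-Glo and resazurin assay, with a stated time of 72 h; a higher number here means that more compound is needed for the effect, a lower number that less compound is needed. Compound 1 is `CC(=O)Nc1cccc(-c2ccc(C(=O)N(Cc3cccc(OCCCCCC(=O)O)c3)C(C)C)cc2)c1`. In this assay compound 1 gives only a limit of the assay, > 26000 nM. Compound 2 is `CC(C)N(Cc1cccc(OCCCCCC(=O)O)c1)C(=O)c1ccc(-c2ccoc2)cc1`. For compound 2 the reading in this assay is likewise a limit, > 26000 nM. Compound 3 is `COc1cc(F)cc(-c2ccc(C(=O)N(Cc3cccc(OCCCCCC(=O)O)c3)C(C)C)cc2)c1`. Compound 3 too reaches only a limit in this assay, > 26000 nM. All three readings sit at the limit of > 26000 nM in this assay, at which 3 of the 3 values shown sit, so compound 2 stands nowhere in particular among them: it is one of three values at the same limit.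

The step to compound 4, `CC(C)N(Cc1cccc(OCCCCCC(=O)O)c1)C(=O)c1ccc(-c2ccc(Cl)c(Cl)c2)cc1`, changes compound 2 in one place: 3,4-dichlorophenyl in place of furan-3-yl on an aromatic carbon. The measured steps that bear on it are a step that the two limits leave unreadable from compound 1 to compound 2 and a step that the two limits leave unreadable from compound 2 to compound 3, both unreadable because the limit of > 26000 nM in this assay, at which 3 of the 3 values shown sit, is where both ends of each sit. The remaining step, a step that the two limits leave unreadable from compound 1 to compound 3, is unreadable in the same way. Among the compounds with values here, no measured step in this assay therefore says how much the group on that aromatic carbon matters. Every measured group there leaves the reading at the limit. Compound 4 is expected to behave in the same way, with an estimated step that the limit leaves unreadable from compound 2 to compound 4. For compound 4 the estimate in this assay is 30000 nM, with a range from 10000 nM to 100000 nM, most likely again reported only as a limit.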

Compound 4, half-maximal effective concentration: > 26000 nM
Compound 4: no number, only a limit; the forecaster's own chance of this, stated with the estimate: 85%; the middle value is on the limit's open side.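

In this assay compound 4 also gives only a limit, > 26000 nM. No step linking compound 4 with compound 1, compound 2 or compound 3 can be read, because every reading stands at the same limit: the limit of > 26000 nM in this assay, at which 4 of the 4 values shown sit.

The compounds shown leave open whether any group on that aromatic carbon can bring a measurable number in this assay.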